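Swapping a Methyl for a Nitro Group

A few compounds are considered here, and "the series" means these few. Any claim that something is new, unique, unknown or untested is made for them only; others in the source may bear on it.

Of the compounds shown here, three sharing one core have been tested in a toxicity assay on the whole organism with Rattus norvegicus as the target, at a dose of 100 mg/kg by the oral route; on this read-out lower numbers stand for a weaker effect and higher numbers for a stronger effect at the one dose given. Compound 1, with the structure `Cc1ccccc1OCC1=NCCO1`, gives 40% in this assay. Compound 2, with the structure `Cc1cc(OCC2=NCCO2)ccc1Cl`, gives 50%. Compound 3, with the structure `Brc1ccc(OCC2=NCCO2)cc1`, gives 60%. Compound 1 thus carries the lowest of the three numbers, but its gap to compound 2 lies within the usual scatter of this kind of measurement, so those two cannot really be told apart; only the gap to compound 3 is wide enough to count as a real difference.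

Compound 4, with the structure `O=[N+]([O-])c1ccccc1OCC1=NCCO1`, has not been measured. It differs from compound 1 in one place: nitro in place of methyl on an aromatic carbon. Going by the values given here, no pair of measured compounds shows this exchange, so its effect is unknown from the numbers at hand. The expected step from compound 1 to compound 4 is a number 10 percentage points higher from compound 1 to compound 4 (within the scatter), a modest rise that stays inside the scatter. Compound 4 is estimated to give 50% in this assay, with a plausible range from 30% to 70%.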

Compound 4, a percentage reported as activity, at one dose (the size of the read-out at that dose, not a potency): 30%
Compound 4: the middle estimate sits 20 percentage points above what was measured; the range from low to high includes it.
By their numbers in this assay, from the lowest: compounds 4, 1, 2 and 3 (each within the scatter of the next, the first and the last beyond it).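

In this assay, exchanging methyl for nitro on this aromatic carbon, ortho to a group of 7 heavy atoms, gives a number 10 percentage points lower from compound 1 to compound 4 (within the scatter) and so leaves compound 1 and compound 4 indistinguishable. The entering nitro brings 3 heavy atoms and 2 hydrogen-bond acceptors where methyl has 1 heavy atom and no acceptor, yet this difference in make-up produces no step beyond the scatter. Going by these compounds alone, until now this position had been seen carrying methyl alone, so this is the first sign that the read-out can hold steady when a quite different group sits there.

As far as these compounds go, whether an amine, a carboxylic acid or a longer chain on this same carbon would also stay within the scatter remains open. Nothing at hand offers an explanation for why the read-out stays so close across this exchange.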